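The compounds below may be only part of what the source reports. "The series", "measured", "known", "first", "only" and "open" are said of these compounds alone.

Of the compounds shown here, three that share one core have been measured in an assay on DDT1 cells (Cricetulus griseus) for binding affinity to adenosine receptor A1 (Homo sapiens), read by radioligand binding; a higher number here means a weaker inhibitor, a lower number a stronger inhibitor. Compound 1 `CNC(=O)OC[C@H]1OC(n2cnc3c(NC4CCOC4)nc(Cl)nc32)[C@H](O)[C@@H]1O` gives 96 nM in this assay. Among the compounds with values here, compound 3 `O=C(NC1CCCC1)OC[C@H]1OC(n2cnc3c(NC4CCOC4)nc(Cl)nc32)[C@H](O)[C@@H]1O` gives 226 nM in this assay, and the step of a 2.4-fold higher number from compound 1 to compound 3 (0.37 log units; beyond the scatter) is the only measured change between two compounds that differ in a single place. Compound 2 `CCCC/N=C(\S)OC[C@H]1OC(n2cnc3c(NC4CCOC4)ncnc32)[C@H](O)[C@@H]1O` gives 157 nM in this assay, the second highest of the three numbers; its value and that of compound 3 lie within the usual scatter of each other, and the same holds for its value and that of compound 1.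

Compound 4 `O[C@@H]1[C@@H](CO/C(S)=N/C2CCCC2)OC(n2cnc3c(NC4CCOC4)ncnc32)[C@@H]1O` has not yet been measured. It differs from compound 2 in one place: cyclopentyl in place of butyl on a double-bonded nitrogen. Within the data shown here, the only measured step that bears on this is a 2.4-fold higher number from compound 1 to compound 3 (0.37 log units; beyond the scatter), where a cyclopentyl also entered, though there it replaced a methyl on an amide-type nitrogen, whereas here it replaces a butyl on a double-bonded nitrogen. That step was modest. In this assay compound 4 is therefore expected to give a number close to that of compound 2 or a little higher, with an expected step of a 1.4-fold higher number from compound 2 to compound 4 (0.15 log units; within the scatter). The estimate for compound 4 in this assay is 220 nM, with a range from 110 nM to 450 nM.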

Compound 4, inhibition constant: 72 nM
Compound 4: middle estimate off by 3.1-fold (0.49 log units), on the high side, and the stated range ends above it.
By their numbers in this assay, from the lowest: compounds 4, 1, 2 and 3 (each within the scatter of the next, the first and the last beyond it).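

In this assay, replacing butyl with cyclopentyl on the double-bonded nitrogen gives a 2.2-fold lower number from compound 2 to compound 4 (0.34 log units; beyond the scatter), so a change at this position can move the number beyond the usual scatter and toward a stronger inhibitor. Cyclopentyl therefore does not push the number the same way in every setting: the other measured step, a 2.4-fold higher number from compound 1 to compound 3 (0.37 log units; beyond the scatter), runs in the opposite direction, with cyclopentyl replacing methyl on an amide-type nitrogen. These two pairs differ in the group that leaves and in the surroundings of the nitrogen, and no available evidence accounts for the opposite directions.

A pentyl chain on the double-bonded nitrogen would help separate the effect of closing the carbon chain into a ring from that of adding one more carbon, while cyclobutyl and cyclohexyl would show how the number changes with ring size. A butyl group on the amide-type nitrogen and a methyl group on the double-bonded nitrogen would then help show whether the direction of the step follows the type of nitrogen or the group being replaced.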